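This account rests on a few compounds, and the source may have more. Where it says the series, first, only, none or still open, it means among the compounds named here.

Measured compounds:
compound 1 `CCC(=O)N1CCN(S(=O)(=O)c2ccc(F)cc2)CC1` — 0.01 mg/kg
compound 2 `CC(=O)N1CCN(S(=O)(=O)c2ccc(F)cc2)CC1` — 0.01 mg/kg

Both were run in a functional assay on the whole organism with Mus musculus as the target, with a stated time of 30 min; on this read-out lower numbers stand for an effect already at smaller amounts and higher numbers for an effect only at larger amounts of compound. The step of no change at the digits printed from compound 1 to compound 2 (within the scatter) was flat, so compound 2 stands level with compound 1 at the digits given; within this pair there is no ordering. Compound 3 `CCCN1CCN(S(=O)(=O)c2ccc(F)cc2)CC1` is the next member. Its difference from compound 2 is propyl in place of acetyl on an amine nitrogen in a ring. Among the compounds with values here, the only measured step, from compound 1 to compound 2, alters the chain on the carbonyl side and keeps the acetyl carbonyl; it therefore says little about a change in which the acetyl leaves and propyl enters on the amine nitrogen in the ring, and no other pair speaks to it. The expectation for a 3.0-fold higher number from compound 2 to compound 3 (0.48 log units; beyond the scatter) is thus loosely held: a modest loss at most, with a wide band either way. Compound 3 is estimated at 0.03 mg/kg, with a range from 0.003 mg/kg to 0.3 mg/kg.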

Compound 3, minimum effective dose: 1 mg/kg
Beside the measured number, compound 3's estimate is 33-fold (1.52 log units) below it, and the stated range ends below it.
By their numbers in this assay, from the lowest: compounds 1 and 2 (each within the scatter of the next); then compound 3.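

In this assay, the amine nitrogen in the ring proves a sensitive place: propyl in place of acetyl gives (a 100-fold higher number from compound 2 to compound 3 (2.00 log units; beyond the scatter)) and propyl in place of propanoyl gives (a 100-fold higher number from compound 1 to compound 3 (2.00 log units; beyond the scatter)), whereas the earlier change on the carbonyl side was flat (no change at the digits printed from compound 1 to compound 2 (within the scatter)). Acetyl and propyl have the same count of 3 heavy atoms, so that count does not follow the step; the printed difference is the carbonyl, present in compounds 1 and 2 and absent from compound 3. No measurement in hand speaks to the cause of this large step.

Going by these compounds, whether the carbonyl itself is what counts remains open, since a urea, a carbamate or a benzoyl on this nitrogen would test that directly. Also open, on these data alone, is whether a methyl or a longer acyl chain such as butanoyl would follow compound 3 or stay level with compounds 1 and 2.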